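The compounds below may be only part of what the source reports. "The series", "measured", "known", "first", "only" and "open" are said of these compounds alone.

Three compounds of a shared core have been taken through an ADME assay on Caco-2 cells (Homo sapiens) for permeability, read by LC-MS, in the apical to basolateral direction, with a stated time of 60 min, at pH 6.5; on this read-out higher numbers stand for higher permeability and lower numbers for lower permeability. Compound 1 `O=C(NCc1cc(Cl)ccc1-n1cnnn1)[C@@H]1C[C@@H]2C[C@@H]2N1C(=O)[C@H](O)Cc1ccccn1` gives 1.2 10^-6 cm/s. Compound 2 `CCCC[C@@H](O)C(=O)N1N=CC[C@H]1C(=O)NCc1cc(Cl)ccc1-n1cnnn1` gives 9.8 10^-6 cm/s, which is the second highest of the three numbers; it lies nearest to compound 3 `CC(C)(C)C[C@@H](O)C(=O)N1[C@@H]2C[C@@H]2C[C@H]1C(=O)NCc1cc(Cl)ccc1-n1cnnn1`, which gives 24 10^-6 cm/s, and furthest from compound 1. Compound 4 `Cc1cccc([C@@H](O)C(=O)N2N=CC[C@H]2C(=O)NCc2cc(Cl)ccc2-n2cnnn2)c1` is not yet measured in this assay. It differs from compound 2 by one change: 3-methylphenyl in place of butyl on a saturated chain carbon bound to a carbonyl carbon and an oxygen on a saturated carbon. Among the compounds with values here, with no measured pair isolating this change, only an expectation can be given: compound 4 is expected to move from compound 2 by about a 1.2-fold higher number from compound 2 to compound 4 (0.09 log units; within the scatter), a step that may well stay within the scatter of repeated measurements. Compound 4 is therefore estimated at 12 10^-6 cm/s, with a range from 5 10^-6 cm/s to 28 10^-6 cm/s.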

Compound 4, apparent permeability: 9.7 10^-6 cm/s
Beside the measured number, compound 4's estimate is 1.2-fold (0.09 log units) above it; measured number inside the range.
By their numbers in this assay, from the lowest: compound 1; then compounds 4 and 2 (each within the scatter of the next); then compound 3.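

At the saturated chain carbon bound to a carbonyl carbon and an oxygen on a saturated carbon, this assay now gives a first isolated step, 3-methylphenyl in place of butyl: a 1.0-fold lower number from compound 2 to compound 4 (0.00 log units; within the scatter). On this core, exchanging the open chain for an aromatic ring of carbon only, with 7 heavy atoms in place of 4, leaves the read-out within the scatter. No measurement shown accounts for this.

As far as these compounds go, whether an amine or a carboxylic acid at this position would move the number remains open. So does whether 3-methylphenyl would give the same result on the core of compound 3.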